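Pyridyl amide to pyridylmethyl amide on a shared core

The source may report more compounds than this note shows. Statements on the series, on what has been measured and on what is new or still open speak of the compounds shown alone.

In an ADME assay on RAW264.7 cells (Mus musculus) for cytotoxicity, read by MTT assay, with a stated time of 72 h, tested at 100 uM (a lower number here means a weaker effect, a higher number a stronger effect of the compound at the concentration tested), compound 1 `O=C(Cn1c(=O)oc2cc([N+](=O)[O-])ccc21)Nc1ccccn1` gives 47.3%. Compound 2 `O=C(Cn1c(=O)oc2cc(Cl)ccc21)Nc1ccccn1` gives 43.7% in this assay, and the step of a number 3.6 percentage points lower from compound 1 to compound 2 (within the scatter) lies within the scatter. Of the two measured numbers compound 2 stands lowest, with compound 1 its nearest neighbour, the two within the scatter of each other. Compound 3 `O=C(Cn1c(=O)oc2cc(Cl)ccc21)NCc1ccccn1` has not been measured. It differs from compound 2 in one place: (pyridin-2-yl)methyl in place of pyridin-2-yl on an amide-type nitrogen. Going by the values given here, the only measured step concerns a substituent on an aromatic carbon and not the amide-type nitrogen, so no measured step bears directly on this change, and that step was itself small. With the two measured numbers this close and no guidance from the amide side, compound 3 is expected to move by a number 0.3 percentage points higher from compound 2 to compound 3 (within the scatter), a step not beyond the scatter. Compound 3 is therefore estimated at 44% in this assay, between 30% and 58%.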

Compound 3, a percentage reported as inhibition, at one concentration (the size of the read-out at that concentration, not a potency): 40%
The estimate for compound 3 lay 4 percentage points above the measured number; the range from low to high includes it.
By their numbers in this assay, from the lowest: compounds 3, 2 and 1 (each within the scatter of the next).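

On the amide-type nitrogen, with the chloro group held constant on the shared core, the step to (pyridin-2-yl)methyl from pyridin-2-yl is a number 3.7 percentage points lower from compound 2 to compound 3 (within the scatter) in this assay. Going by these compounds alone, this gives the first reading at this position and shows that this change on the amide side, like the step of a number 3.6 percentage points lower from compound 1 to compound 2 (within the scatter) on the aromatic carbon, does not separate the compounds in this read-out. Nothing measured in this account offers an explanation for either outcome.

As far as these compounds go, the (pyridin-2-yl)methyl group appears here only with chloro on the shared core, so whether the same step would hold with nitro remains open. Also open, from the compounds shown here alone, is how the read-out would respond on the amide-type nitrogen to a phenyl ring, a longer chain ending in pyridine, or a chain carrying an amine or a carboxylic acid.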